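This account rests on a few compounds, and the source may have more. Where it says the series, first, only, none or still open, it means among the compounds named here.

Of the compounds shown here, three built on one shared core have been tested in an assay on cell membranes from Cerebral cortex for displacement of a labelled ligand from Sigma non-opioid intracellular receptor 1 (Cavia porcellus), read by scintillation counting, with a stated time of 120 min; on this read-out higher numbers stand for weaker inhibition and lower numbers for stronger inhibition. Compound 1 `CN(CCCCn1ccc2ccccc21)Cc1ccc(Cl)cc1` gives 4400 nM in this assay. Compound 2 `CN(CCCCN1C(=O)OC[C@H]1c1ccccc1)Cc1ccc(Cl)cc1` gives 2.9 nM, the lowest of the three numbers and therefore the strongest inhibition seen so far. Compound 3 `CN(CCCCn1nc(-c2ccccc2)oc1=O)Cc1ccc(Cl)cc1` gives 18.7 nM. Compound 2 stands clearly apart: its nearest neighbour is compound 3, whose number lies beyond the scatter above it, and the furthest is compound 1, whose number lies far beyond the scatter.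

Compound 4 `CN(CCCCN1C(=O)OCC1c1ccccc1)Cc1ccc(Cl)cc1` is now to be measured in this assay. It keeps every atom and bond of compound 2; the only difference is the two compounds have the same atoms and bonds; at least one stereo element is drawn with a configuration in one of them and without one in the other: 1 of 1 stereo elements differ; a stereocentre at a saturated ring carbon is drawn R in compound 2 and without a configuration in compound 4. In plain terms, compound 2 is drawn as a single configuration at that ring carbon, while compound 4 is drawn with no configuration there, as would be the case for a material containing both mirror-image forms. Among the measured compounds shown here, none of the measured pairs differ in this way, so there is no measured step to lean on. If only one of the two forms carries the activity, a small rise in the number is expected; if both contribute, no step beyond the scatter is expected. The step from compound 2 to compound 4 is estimated as a 1.9-fold higher number from compound 2 to compound 4 (0.28 log units; within the scatter), giving compound 4 an expected 5.5 nM, within a range of 2.5 nM to 15 nM.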

Compound 4, inhibition constant: 0.95 nM
Compound 4: the middle estimate sits 5.8-fold (0.76 log units) above what was measured; the whole stated range lies above it.
By their numbers in this assay, from the lowest: compound 4; then compound 2; then compound 3; then compound 1.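

Until now, nothing had shown whether the spatial arrangement at this saturated ring carbon matters in this assay, and here the number moves with atoms and bonds unchanged, giving a 3.1-fold lower number from compound 2 to compound 4 (0.48 log units; beyond the scatter). If compound 4 does contain both mirror-image forms, the R form drawn in compound 2 cannot be the only one carrying the activity, since diluting a sole active form would raise the number rather than lower it, so the form drawn S would have to bind at least as strongly. This reading rests on a single structural feature: the fact that one of compounds 2 and 4 is drawn with a defined configuration and the other without, at the place where they differ.

The compounds shown leave open how the S form alone would read, and what proportion of each form compound 4 actually contains, so the size of any gap between the two mirror-image forms remains unknown. They also leave open whether this sensitivity to arrangement would persist if a methyl group took the place of the phenyl group at that ring carbon, or if a longer chain replaced the butyl chain joining the shared core to the amine.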